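This account rests on a few compounds, and the source may have more. Where it says the series, first, only, none or still open, it means among the compounds named here.

Measured in an ADME assay on HaCaT cells (Homo sapiens) for inhibition, read by sulforhodamine B assay, with a stated time of 48 h; a higher number here means a weaker inhibitor of growth, a lower number a stronger inhibitor of growth:
- Compound 1 `Ic1ccc(Cn2cc(CCCOc3cccc4cccnc34)nn2)cc1`: > 250 ug/mL
- Compound 2 `Clc1ccc(Cn2cc(CCCOc3cccc4cccnc34)nn2)cc1`: 4.2 ug/mL

The entry for compound 1 is a limit of the assay and not a number: the limit of > 250 ug/mL in this assay, at which 1 of the 2 values shown sits. Compound 3 `Fc1ccc(Cn2cc(CCCOc3cccc4cccnc34)nn2)cc1F` has not yet been measured in this assay. Its change from compound 1 is 3,4-difluorophenyl in place of 4-iodophenyl on a saturated chain carbon bound to an aromatic nitrogen. Going by the values given here, one measured step bears on this, chloro in place of iodo on an aromatic carbon, and it was large: an at least 59-fold lower number from compound 1 to compound 2 (1.77 log units; beyond the scatter). That step also removes the iodo group, so a large move toward a lower number is expected here too, though it involves a different replacement. The expected step is an at least 20-fold lower number from compound 1 to compound 3 (1.31 log units; beyond the scatter). For compound 3 the estimated value is 12 ug/mL, with an expected range from 3 ug/mL to 100 ug/mL.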

Compound 3, concentration for 50% growth inhibition: 41.7 ug/mL
For compound 3 the middle estimate is 3.5-fold (0.54 log units) below the measured one; low and high end bracket the measured number.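

In this assay, the lower number is not confined to the chloro replacement, since 3,4-difluorophenyl in place of 4-iodophenyl also gives an at least 5.9-fold lower number from compound 1 to compound 3 (0.77 log units; beyond the scatter). Compound 1 stands only as a limit of the assay, not a number: the limit of > 250 ug/mL in this assay, at which 1 of the 3 values shown sits. The two replacements are not equivalent, with a 9.9-fold higher number from compound 2 to compound 3 (1.00 log units; beyond the scatter), so the result at this position depends on which group enters as well as on the loss of 4-iodophenyl.

From the compounds shown here alone, compound 2 and compound 3 differ in both the kind and the count of halogen, and which of these carries the gap stays open. Also open, going by these compounds, is how a phenyl bearing an amine or a methoxy group would read.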